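Amide swap on a bromonaphthyridine carboxamide: estimating compound 4

A few compounds are considered here, and "the series" means these few. Any claim that something is new, unique, unknown or untested is made for them only; others in the source may bear on it.

Measured compounds:
- compound 1 `O=C(NCc1ccc(F)cc1)c1nc(Br)c2cccnc2c1NCCCNc1c(C(=O)NCc2ccc(F)cc2)nc(Br)c2cccnc12`: > 20000 nM
- compound 2 `N[C@H]1CC[C@H](Nc2c(C(=O)NCc3ccccn3)nc(Br)c3cccnc23)CC1`: "not determined" (no result reported)
- compound 3 `NCCCNc1c(C(=O)NCc2ccc(F)cc2)nc(Br)c2cccnc12`: > 20000 nM

In a functional assay on HCT-116 cells (Homo sapiens) for cytotoxicity, read by MTT assay, with a stated time of 72 h (on this read-out lower numbers stand for stronger inhibition and higher numbers for weaker inhibition), compound 1 reaches only a limit of the assay, > 20000 nM. Compound 3 likewise reaches only a limit, > 20000 nM. As far as these compounds go, for compound 2 no result was reported in this assay, "not determined" (no result reported), so its standing among the numbers is unknown; the two values that exist are both (the limit of > 20000 nM in this assay, at which 2 of the 3 values shown sit), and neither is a number.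

Compound 4 `C[C@H](NC(=O)c1nc(Br)c2cccnc2c1N[C@H]1CC[C@H](N)CC1)c1ccc(F)cc1` differs from compound 2 in one place: 1-(4-fluorophenyl)ethyl in place of (pyridin-2-yl)methyl on an amide-type nitrogen. The amide nitrogen keeps its carbonyl carbon neighbour, while the group on it changes from (pyridin-2-yl)methyl to 1-(4-fluorophenyl)ethyl.

Among the measured compounds shown here, no measured pair shows a comparable change, and compound 2 itself carries no number, so the size and direction of the step cannot be anchored; the expectation is therefore wide. Compound 4 is estimated to give about 6000 nM in this assay, within a range from 1000 nM to 20000 nM, with a real chance that only a limit is reported.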

Compound 4, half-maximal inhibitory concentration: > 10000 nM
Compound 4 was reported as a limit (the forecaster's own chance of this, stated with the estimate: 40%); middle value at least 1.6-fold (0.22 log units) from the limit.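

In this assay compound 4 gives > 10000 nM, which is a limit and not a number. Compound 2 carries no value to compare it with, so no step can be read between these two compounds. The compounds shown leave open how far, and in which direction, replacing (pyridin-2-yl)methyl with 1-(4-fluorophenyl)ethyl shifts cytotoxicity.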